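Adding a Second Chloro to a Purine Cytotoxic Series

This account rests on a few compounds, and the source may have more. Where it says the series, first, only, none or still open, it means among the compounds named here.

The study gathers three measured purine derivatives and one that awaits measurement. Compound 1 `ClCc1ccc(Cn2cnc3c(Cl)ncnc32)cc1` carries a single chloro on the shared core and a chloromethyl-bearing benzyl group. In a functional assay on BT-549 cells (Homo sapiens) for cytotoxicity, read by sulforhodamine B assay, with a stated time of 48 h (on this read-out lower numbers stand for higher toxicity in this test and higher numbers for lower toxicity in this test), compound 1 gives 57500 nM. Compound 3 `Nc1nc(Cl)c2ncn(Cc3ccccc3CCl)c2n1`, an amino-bearing analogue, gives 57500 nM in this assay, so compound 1 stands level with compound 3 at the digits shown, and together they hold the highest numbers of the three. Compound 2 `ClCc1cccc(Cn2cnc3c(Cl)nc(Cl)nc32)c1`, which carries two chloro groups on the core, gives 6160 nM in this assay, a number well beyond the scatter below that of compound 1.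

The unmeasured compound 4 `ClCc1ccc(Cn2cnc3c(Cl)nc(Cl)nc32)cc1` differs from compound 1 in one place: chloro in place of hydrogen on an aromatic carbon. Within the data shown here, no measured pair shows exactly this change, so the size of the step has to be judged from compound 2, whose value 6160 nM is the only one in this set from a core bearing two chloro groups. On that basis compound 4 is expected to show a clearly lower number than compound 1, a step of a 6.4-fold lower number from compound 1 to compound 4 (0.81 log units; beyond the scatter) beyond the scatter. Compound 4 is therefore estimated at 9000 nM, with a range from 3000 nM to 30000 nM.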

Compound 4, concentration lethal to 50% of the cells: 56200 nM
The estimate for compound 4 lay 6.2-fold (0.80 log units) below the measured number; the measured number lies above the stated range.
By their numbers in this assay, from the lowest: compound 2; then compounds 4, 1 and 3 (each within the scatter of the next).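

On the aromatic carbon between two ring nitrogen atoms, chloro in place of hydrogen gives a 1.0-fold lower number from compound 1 to compound 4 (0.01 log units; within the scatter) in this assay, so in this test the added chloro cannot be told from the hydrogen it replaces. Compound 4 carries the same two chloro groups on the core as compound 2, yet compound 4 gives 56200 nM and compound 2 gives 6160 nM; these two differ in where the chloromethyl group stands on the benzyl group, so a core bearing two chloro groups does not by itself go with the lower number. Nothing available gives a reason for this result.

On these data alone, what remains open is whether a methyl or a methoxy group on the same carbon would likewise leave the number within the scatter of compound 1, or whether the flat result belongs to chloro alone. Among these compounds, also open is whether hydrogen and chloro on this carbon would stay level when the chloromethyl group stands as it does in compound 2, the one compound here whose number lies well apart from the rest.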